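The source may report more compounds than this note shows. Statements on the series, on what has been measured and on what is new or still open speak of the compounds shown alone.

Working notes on the series.

Compound 1 `Cc1cccc(-c2nn3c(c2-c2ccncc2)CC(C)(C)C3)n1` is the parent. In a functional assay on K562 cells (Homo sapiens) for cytotoxicity, with a stated time of 72 h (on this read-out lower numbers stand for stronger inhibition and higher numbers for weaker inhibition), compound 1 gives > 100000 nM, which is a limit of the assay and not a number. Compound 2 `Cc1cccc(-c2nn3c(c2-c2ccnc(Cl)c2)CC(C)(C)C3)n1` carries the change chloro in place of hydrogen on an aromatic carbon relative to compound 1. In this assay compound 2 gives > 100000 nM, again a limit. The step that the two limits leave unreadable from compound 1 to compound 2 therefore cannot be sized, because the limit of > 100000 nM in this assay, at which 3 of the 3 values shown sit, holds both ends of it.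

Compound 3 `Cc1cccc(-c2nn3c(c2-c2ccncc2)C(C)C(C)(C)C3)n1` differs from compound 1 in the core: methyl in place of hydrogen on a saturated ring carbon. In this assay compound 3 gives > 100000 nM, also a limit. The step that the two limits leave unreadable from compound 1 to compound 3 is likewise unreadable, because the limit of > 100000 nM in this assay, at which 3 of the 3 values shown sit, covers all three values recorded so far.

Compound 4 `Cc1cccc(-c2nn3c(c2-c2ccnc(Cl)c2)C(C)C(C)(C)C3)n1` has not yet been measured. Relative to compound 3 it carries chloro in place of hydrogen on an aromatic carbon. Going by the values given here, this is the same change as the one from compound 1 to compound 2, and the description of the place is identical word for word for both pairs, so the two are the same kind of change on cores that differ as stated for compound 3 against compound 1.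

Expectation for compound 4 in this assay: the earlier instance of this change left compound 2 at the limit, and compound 3 itself sits at the limit, so the step that the limit leaves unreadable from compound 3 to compound 4 is expected to be unreadable in the same way. Compound 4 is estimated at 150000 nM, with a range from 50000 nM to 500000 nM, most likely reported only as a limit.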

Compound 4, half-maximal inhibitory concentration: > 100000 nM
Compound 4: a limit, no number; the forecaster's own chance of this, stated with the estimate: 85%; the middle value does not contradict the limit.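

In this assay compound 4 gives > 100000 nM as a limit of the assay and not a number. No new step can be read from compound 4 to compound 3 or compound 2, because both ends of each step are held by one limit: the limit of > 100000 nM in this assay, at which 4 of the 4 values shown sit. The compounds shown leave open how large the chloro and methyl changes on the shared core are in this assay.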